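The source may hold more compounds than are shown below. What is called first, only, known or untested is meant among the compounds shown, and "the series" means these compounds.

Of the compounds shown here, three in this set have been measured in an assay (Equus caballus) for inhibition of Thromboxane-A synthase (Homo sapiens), using microsomes; a lower number here means a stronger inhibitor, a higher number a weaker inhibitor. Compound 1 `O=C(O)CCCC/C=C(/c1ccc(Br)cc1)c1cccnc1` gives 82 nM. Compound 2 `COc1ccc(/C(=C/CCCCC(=O)O)c2cccnc2)cc1` gives 80 nM; it differs from compound 1 in one place, a methoxy in place of a bromo on an aromatic carbon, and the step of a 1.0-fold lower number from compound 1 to compound 2 (0.01 log units; within the scatter) is within the usual scatter. Compound 3 `O=C(O)CCCCCCCCC/C=C(\c1ccccc1)c1cccnc1` gives 55 nM. Compound 1 stands at the upper end of these three numbers, but its gap to compound 2 and its gap to compound 3 are both small enough to count as scatter rather than as real differences, so the three compounds cannot be told apart here.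

Compound 4 `Cc1ccsc1/C(=C/CCCCC(=O)O)c1cccnc1` has not yet been measured. It differs from compound 1 as follows: 3-methylthiophen-2-yl in place of 4-bromophenyl on a double-bonded chain carbon bound to an aromatic carbon and a double-bonded chain carbon. For the measured compounds named here, the only measured step that touches this part of the molecule is the one from compound 1 to compound 2, which exchanged a single substituent on the ring and moved nothing beyond the scatter. Here the whole ring is exchanged, so that step is only a loose guide, and compound 3 adds that a third variant also lands close to the other two. With nothing in the data pointing to a shift, compound 4 is expected to stay close to compound 1, with a step of a 1.0-fold lower number from compound 1 to compound 4 (0.01 log units; within the scatter) that is itself expected to remain within the scatter. The estimate for compound 4 is 80 nM, with a range from 30 nM to 220 nM.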

Compound 4, half-maximal inhibitory concentration: 29 nM
Beside the measured number, compound 4's estimate is 2.8-fold (0.44 log units) above it, and the stated range ends above it.
By their numbers in this assay, from the lowest: compounds 4, 3, 2 and 1 (each within the scatter of the next, the first and the last beyond it).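

In this assay, exchanging the whole 4-bromophenyl for 3-methylthiophen-2-yl on the double-bonded chain carbon gives a 2.8-fold lower number from compound 1 to compound 4 (0.45 log units; beyond the scatter) and is the only step shown here that lies beyond the scatter, though it is modest. For the compounds shown here, the earlier exchange of a single ring substituent, a 1.0-fold lower number from compound 1 to compound 2 (0.01 log units; within the scatter) stayed within the scatter, so compound 4 is the first sign that a change at this position can move the number at all. The change takes out a six-membered aromatic ring of carbon only and brings in a five-membered aromatic ring with 1 hetero atom, yet no measurement here accounts for the lower number.

The compounds shown cannot separate the change of ring from the methyl group it carries, and a plain thiophen-2-yl, without the methyl, would be the compound to tell these two apart. They also leave open whether a furan-2-yl ring would act in the same way at this position, and whether the step would hold on the longer chain of compound 3.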